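Neopentyl in place of tert-butoxycarbonyl: what to expect

A few compounds are considered here, and "the series" means these few. Any claim that something is new, unique, unknown or untested is made for them only; others in the source may bear on it.

- Compound 1 `CCN1CCc2c(sc(NC(=O)Nc3ccc(Cl)cc3)c2C(N)=O)C1`: 3120 nM
- Compound 2 `CC(C)(C)OC(=O)N1CCc2c(sc(NC(=O)Nc3ccc(Cl)cc3)c2C(N)=O)C1`: > 25000 nM (a limit, not a number)
- Compound 3 `CC(C)(C)CN1CCc2c(sc(NC(=O)Nc3ccc(Cl)cc3)c2C(N)=O)C1`: not yet measured

The assay here is a functional assay (strain AB) with Danio rerio as the target, read by microscopy, with a stated time of 1 h; a lower number here means that less compound is needed, a higher number that more compound is needed for the effect. In this assay, compound 1 gives 3120 nM. Compound 2 gives > 25000 nM, which is a limit of the assay. Compound 2 therefore stands at the limit of > 25000 nM in this assay, at which 1 of the 2 values shown sits.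

The next change puts neopentyl in place of tert-butoxycarbonyl on an amine nitrogen in a ring.

Among the compounds with values here, only one measured step touches this nitrogen: an at least 8.0-fold higher number from compound 1 to compound 2 (0.90 log units; beyond the scatter), where tert-butoxycarbonyl took the place of ethyl. Compound 3 loses tert-butoxycarbonyl again and carries an all-carbon group, as ethyl is in compound 1, so the expectation leans on compound 1 at 3120 nM. Neopentyl is not ethyl, however, and a single step is thin support, so the range is kept wide and reaches up to the limit.

The expected change is an at least 5.0-fold lower number from compound 2 to compound 3 (0.69 log units; beyond the scatter), towards a lower number in this assay. For compound 3 the estimated value is 5000 nM, with an expected range from 1200 nM to 25000 nM.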

Compound 3, half-maximal effective concentration: 5560 nM
Compound 3: middle estimate off by 1.1-fold (0.05 log units), on the low side; the measured number falls inside the stated range.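

In this assay, neopentyl in place of tert-butoxycarbonyl on the amine nitrogen in a ring gives an at least 4.4-fold lower number from compound 2 to compound 3 (0.65 log units; beyond the scatter). Both groups end in the same branched tert-butyl unit, so that unit alone does not go with the high number of compound 2, and what separates compound 2 from compound 3 at this nitrogen is the carbonyl and oxygen that leave. The all-carbon groups also cannot be told apart here, since the step from ethyl to neopentyl is a 1.8-fold higher number from compound 1 to compound 3 (0.25 log units; within the scatter), and compound 2 gives a limit rather than a number, so the full size of its gap to compound 3 stays unknown: the limit of > 25000 nM in this assay, at which 1 of the 3 values shown sits.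

From the compounds shown here alone, it remains open which part of tert-butoxycarbonyl goes with the high number, and an acetyl group on the same nitrogen would keep the carbonyl without the oxygen in the chain. A benzyl group or a hydroxyethyl chain at this nitrogen would show whether the range of tolerated groups reaches beyond simple saturated carbon chains, and all three compounds share the rest of the core, so nothing here speaks to changes elsewhere.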